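The source may hold more compounds than are shown below. What is called first, only, known or untested is meant among the compounds shown, and "the series" means these compounds.

Compound 1 `C[C@@H](Nc1c(C(=O)NCc2ccc(F)cc2)nc(Br)c2cccnc12)c1ccccc1` reaches only the limit of a functional assay on MDA-MB-435 cells (Homo sapiens) for cytotoxicity, read by MTT assay, with a stated time of 72 h (on this read-out lower numbers stand for stronger inhibition and higher numbers for weaker inhibition), at > 20000 nM. Compound 2 `N[C@H]1CC[C@H](Nc2c(C(=O)NCc3ccccn3)nc(Br)c3cccnc23)CC1` gives 4000 nM in this assay, and compound 3 `N[C@H]1CC[C@H](Nc2c(C(=O)NCc3ccc(Cl)cc3Cl)nc(Br)c3cccnc23)CC1` gives 5800 nM, a value that sits alongside that of compound 2, since a 1.5-fold higher number from compound 2 to compound 3 (0.16 log units; within the scatter) stays within the scatter; no other number is reported. Compound 4 `N[C@H]1CC[C@H](Nc2c(C(=O)NCc3ccccc3)nc(Br)c3cccnc23)CC1` differs from compound 3 by phenyl in place of 2,4-dichlorophenyl on a saturated chain carbon bound to an amide-type nitrogen. Among the measured compounds shown here, the one step that bears on this change is a 1.5-fold higher number from compound 2 to compound 3 (0.16 log units; within the scatter), which exchanged pyridin-2-yl for 2,4-dichlorophenyl on a saturated chain carbon bound to an amide-type nitrogen without moving the number beyond the scatter; the exchange of 2,4-dichlorophenyl for phenyl is therefore expected to give no step beyond the scatter either. Compound 4 is thus estimated at 5000 nM, between 2000 nM and 15000 nM, an expected change of a 1.2-fold lower number from compound 3 to compound 4 (0.06 log units; within the scatter).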

Compound 4, half-maximal inhibitory concentration: 7000 nM
Compound 4: the middle estimate sits 1.4-fold (0.15 log units) below what was measured; the range from low to high includes it.
By their numbers in this assay, from the lowest: compounds 2, 3 and 4 (each within the scatter of the next). At a limit, above all of these: compound 1.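

In this assay the two chlorines of the 2,4-dichlorophenyl group prove dispensable at this place, with a 1.2-fold higher number from compound 3 to compound 4 (0.08 log units; within the scatter). Plain phenyl also stands level with pyridin-2-yl, with a 1.8-fold higher number from compound 2 to compound 4 (0.24 log units; within the scatter), so all three aromatic rings shown on a saturated chain carbon bound to an amide-type nitrogen give values within the scatter of one another. Nothing shown gives a cause for this lack of difference. Still open, on these data alone, is whether a non-aromatic group at this place, such as a cyclohexyl ring or a carboxylic acid, would move the number beyond the scatter.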